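Shortening the Alkyl Chain from Compound 2 to Compound 3

A few compounds are considered here, and "the series" means these few. Any claim that something is new, unique, unknown or untested is made for them only; others in the source may bear on it.

In a functional assay on MDA-MB-231 cells (Homo sapiens) for inhibition, read by MTT assay, with stated times of 18 h and 4 h (a lower number here means a stronger inhibitor, a higher number a weaker inhibitor), compound 1 `CCCCCCCCCCCCCCCCOP(=O)(O)OCCSC(=S)N1CCN(C)CC1` gives > 100000 nM as a limit of the assay, not a number. Among the measured compounds shown here, compound 2 `CCCCCCCCCCOP(=O)(O)OCCSC(=S)N1CCN(C)CC1` stands at 29000 nM in this assay and holds the only actual number so far. Compound 3 `CCCCCCCCOP(=O)(O)OCCSC(=S)N1CCN(C)CC1` differs from it by hydrogen in place of ethyl on a saturated chain carbon, eight bonds along the chain from an oxygen on an unsaturated carbon. For the measured compounds named here, one measured step bears on this, an at least 3.4-fold lower number from compound 1 to compound 2 (0.53 log units; beyond the scatter), a larger cut of the same chain. A smaller lowering is therefore expected, with the estimated 1.5-fold lower number from compound 2 to compound 3 (0.16 log units; within the scatter) staying within the scatter. For compound 3 the estimate is 20000 nM, ranging from 7000 nM to 70000 nM in this assay.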

Compound 3, half-maximal inhibitory concentration: 58500 nM
For compound 3 the middle estimate is 2.9-fold (0.47 log units) below the measured one, within the range that was stated.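

In this assay, hydrogen in place of ethyl at this place gives a 2.0-fold higher number from compound 2 to compound 3 (0.30 log units; within the scatter) and so leaves compound 2 and compound 3 apart by no more than the scatter, unlike the larger cut of the same chain seen earlier. Against compound 1 the change reads an at least 1.7-fold lower number from compound 1 to compound 3 (0.23 log units; that floor lies within the scatter) as a floor only. That step can be read no further because the value of compound 1 is a limit of the assay, not a number: the limit of > 100000 nM in this assay, at which 1 of the 3 values shown sits.

Still open, on these data alone, is how a shorter chain, or an amine or a carboxylic acid at the chain end, would stand in this assay.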